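Capping the ring hydroxy with a methyl group

The source may report more compounds than this note shows. Statements on the series, on what has been measured and on what is new or still open speak of the compounds shown alone.

In an assay on isolated protein for inhibition of Amine oxidase [flavin-containing] A (Homo sapiens), read by fluorescence (a lower number here means a stronger inhibitor, a higher number a weaker inhibitor), compound 1 `N#Cc1cc2c(Br)c(-c3ccccc3)n(O)c2cc1C#N` gives 3480 nM. Going by the values given here, compound 2 `COc1ccc(-c2c(Br)c3cc(C#N)c(C#N)cc3n2O)cc1` gives 726 nM in this assay, and the change a 4.8-fold lower number from compound 1 to compound 2 (0.68 log units; beyond the scatter) is the only measured step available. On these two numbers compound 2 stands lowest, with compound 1 the nearest at a higher value.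

Compound 3 `COc1ccc(-c2c(Br)c3cc(C#N)c(C#N)cc3n2OC)cc1` differs from compound 2 by methyl in place of hydrogen on an oxygen on an aromatic ring. Among the compounds with values here, no measured step touches this oxygen: the single known step concerns the methoxy on an aromatic carbon of the phenyl ring, a different place, so it offers no direct guide. With nothing to show a shift either way, the expected step in this assay is a 1.7-fold higher number from compound 2 to compound 3 (0.22 log units; within the scatter), that is, a change not clearly beyond the scatter, with wide uncertainty. For compound 3 the estimated value in this assay is 1200 nM, within a range from 300 nM to 5000 nM.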

Compound 3, half-maximal inhibitory concentration: > 100000 nM
Compound 3: only a limit was reported; the forecaster's own chance of this, stated with the estimate: 5%; middle value at least 83-fold (1.92 log units) from the limit.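

In this assay, going from hydroxy to methoxy on this oxygen gives an at least 130-fold higher number from compound 2 to compound 3 (2.13 log units; beyond the scatter), so one added methyl here counts for far more than the methoxy added on the phenyl ring, which gave a 4.8-fold lower number from compound 1 to compound 2 (0.68 log units; beyond the scatter). Going by these compounds alone, the earlier compounds changed only that phenyl ring and left the hydroxy free, so they could not show how sensitive this oxygen is to change. Compound 3 carries a limit of the assay rather than a number, so the full size of its step stays unknown: the limit of > 100000 nM in this assay, at which 1 of the 3 values shown sits.

Methyl is the only group shown on this oxygen, so it remains open whether an ethyl chain or an acetyl group would end at the same limit. This change is also shown only on compound 2, so whether the same change on compound 1 would cost as much remains open too.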